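Hydroxyl in Place of Methoxy on a Core at the Limit

The compounds below may be only part of what the source reports. "The series", "measured", "known", "first", "only" and "open" are said of these compounds alone.

Compound 1 `COc1ccccc1Nc1nc(-c2cccc(F)c2)nc2ccc(F)cc12` was examined in a functional assay on MCF7 cells (Homo sapiens) for cytotoxicity, read by MTT assay, with a stated time of 48 h; on this read-out lower numbers stand for stronger inhibition and higher numbers for weaker inhibition. In this assay compound 1 gives > 50000 nM, which is a limit of the assay rather than a number. Compound 2 `Fc1cccc(-c2nc(Nc3ccccc3Cl)c3cc(F)ccc3n2)c1` carries chloro in place of methoxy on an aromatic carbon. In this assay compound 2 gives > 50000 nM, again a limit. Going by the values given here, the one measured step, a step that the two limits leave unreadable from compound 1 to compound 2, is therefore unreadable, and compound 1 stands only at a limit, with both values sitting at the limit of > 50000 nM in this assay, at which 2 of the 2 values shown sit. Compound 3 `Oc1ccc(Nc2nc(-c3cccc(F)c3)nc3ccc(F)cc23)cc1` differs from compound 1 by 4-hydroxyphenyl in place of 2-methoxyphenyl on a nitrogen on an aromatic ring. Among the compounds with values here, no measured step involves a hydroxyl group, so the limit is the only guide and no direction of change can be read from it. The expected step is an at least 1.2-fold lower number from compound 1 to compound 3 (0.09 log units; that floor lies within the scatter). For compound 3 the estimate is 40000 nM, in a range from 8000 nM to 200000 nM.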

Compound 3, half-maximal inhibitory concentration: > 50000 nM
Compound 3 gave a limit, no number; the forecaster's own chance of this, stated with the estimate: 65%; middle value at least 1.2-fold (0.09 log units) away from the limit.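

Going by these compounds alone, compound 3 also gives only a limit, so no step among compound 1, compound 2 and compound 3 can be read: the limit of > 50000 nM in this assay, at which 3 of the 3 values shown sit.

The compounds shown leave open which change to the group on the nitrogen, if any, would give a readable number in this assay rather than a limit.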